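Swapping a chloro for a methyl on the sulfonamide ring

The source may hold more compounds than are shown below. What is called first, only, known or untested is meant among the compounds shown, and "the series" means these compounds.

Three compounds have been measured in a functional assay on 143B cells (Homo sapiens) for antiproliferative activity, read by MTT assay, with a stated time of 48 h; a lower number here means a stronger inhibitor, a higher number a weaker inhibitor:
- compound 1, `O=C(Nc1cccc(/C=C/C(=O)c2nc3ccccc3[nH]2)c1)c1cccc(Cl)c1`, gives 3370 nM
- compound 2, `O=C(Nc1cccc(/C=C/C(=O)c2nc3ccccc3[nH]2)c1)c1ccc(Br)cc1`, gives 7310 nM
- compound 3, `O=C(/C=C/c1cccc(NS(=O)(=O)c2cccc(Cl)c2)c1)c1nc2ccccc2[nH]1`, gives 2510 nM

All three share the same core; they differ only in the group attached to the nitrogen on the aromatic ring. Compound 3 has the lowest number of the three, but its gap to compound 1 is small: a 1.3-fold lower number from compound 1 to compound 3 (0.13 log units; within the scatter). Its gap to compound 2 is larger: a 2.9-fold lower number from compound 2 to compound 3 (0.46 log units; beyond the scatter). Between the two amides, a 2.2-fold higher number from compound 1 to compound 2 (0.34 log units; beyond the scatter).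

Compound 4, `Cc1cccc(S(=O)(=O)Nc2cccc(/C=C/C(=O)c3nc4ccccc4[nH]3)c2)c1`, is built from compound 3 by one change: methyl in place of chloro on an aromatic carbon. Within the data shown here, no measured step touches this exact exchange. Among the measured compounds shown here, the only step that alters a substituent on that outer ring, a 2.2-fold higher number from compound 1 to compound 2 (0.34 log units; beyond the scatter), changes both the halogen and its position at once, so it gives only a loose guide. The two steps to compound 3, a 1.3-fold lower number from compound 1 to compound 3 (0.13 log units; within the scatter) and a 2.9-fold lower number from compound 2 to compound 3 (0.46 log units; beyond the scatter), concern the linker, not the substituent. With so little to go on, the expected step is small, a 1.2-fold higher number from compound 3 to compound 4 (0.08 log units; within the scatter), in no clear direction. Compound 4 is therefore estimated at 3000 nM, with a range from 1200 nM to 8000 nM.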

Compound 4, half-maximal inhibitory concentration: 791 nM
For compound 4 the middle estimate is 3.8-fold (0.58 log units) above the measured one; the measured number lies below the stated range.
By their numbers in this assay, from the lowest: compound 4; then compounds 3 and 1 (each within the scatter of the next); then compound 2.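

In this assay, the outer ring of the sulfonamide proves sensitive to an exchange of one heavy atom for another: methyl in place of chloro gives a 3.2-fold lower number from compound 3 to compound 4 (0.50 log units; beyond the scatter), even though the counts of hydrogen-bond donors and acceptors stay the same. The earlier exchange of amide for sulfonamide, with the 3-chlorophenyl group kept, gave only a 1.3-fold lower number from compound 1 to compound 3 (0.13 log units; within the scatter), so this substituent has now produced a step beyond the scatter where that linker change did not. With the (3-methylphenyl)sulfonyl group in place, the comparisons with the two amides read a 4.3-fold lower number from compound 1 to compound 4 (0.63 log units; beyond the scatter) and a 9.2-fold lower number from compound 2 to compound 4 (0.97 log units; beyond the scatter), though no measurement here offers an explanation for the lower number of compound 4.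

The compounds shown leave open whether an ethyl group, a methoxy group or an amine at this spot would lower the number further, and how the ring would fare with plain hydrogen there. They also leave open whether the same exchange of chloro for methyl would give a similar step on the amide of compound 1, so no general rule can be drawn yet.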